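From Sulfanyl to Amino on a Shared Core

A few compounds are considered here, and "the series" means these few. Any claim that something is new, unique, unknown or untested is made for them only; others in the source may bear on it.

Of the compounds shown here, two built on a shared core have been measured in a functional assay on MV4-11 cells (Homo sapiens) for antiproliferative activity, read by CellTiter-Glo, with a stated time of 72 h; a higher number here means a weaker inhibitor of growth, a lower number a stronger inhibitor of growth. Compound 1 (`COCCN[C@H]1CC[C@H](Nc2cc(-c3csc(NCC4CCOCC4)n3)c(C)cn2)CC1`) gives 1620 nM, while compound 2 (`COCCN[C@H]1CC[C@H](Nc2cc(-c3csc(SCC4CCOCC4)n3)c(Cl)cn2)CC1`) gives 340 nM. That is the lower of the two numbers, which makes compound 2 the stronger inhibitor of growth by a margin beyond the scatter. These two compounds differ in more than one place, so their gap cannot be assigned to any single change.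

Compound 3 (`COCCN[C@H]1CC[C@H](Nc2cc(-c3csc(NCC4CCOC4)n3)c(Cl)cn2)CC1`) has yet to be measured. It departs from compound 2 on an aromatic carbon, where ((oxolan-3-yl)methyl)amino takes the place of ((oxan-4-yl)methyl)sulfanyl: ((oxolan-3-yl)methyl)amino in place of ((oxan-4-yl)methyl)sulfanyl on an aromatic carbon. Going by the values given here, no measured pair isolates this swap, so the expectation rests on little. Among the compounds with values here, the only measured compound with an amino link, compound 1, stands at 1620 nM, which points towards a moderately higher number, though perhaps one not beyond the scatter. The estimated shift in this assay is a 1.5-fold higher number from compound 2 to compound 3 (0.17 log units; within the scatter). For compound 3 the expected value is 500 nM, with an estimated range of 150 nM to 1700 nM.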

Compound 3, concentration for 50% growth inhibition: 493 nM
For compound 3 the middle estimate is 1.0-fold (0.01 log units) above the measured one, within the range that was stated.
By their numbers in this assay, from the lowest: compounds 2 and 3 (each within the scatter of the next); then compound 1.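

In this assay, going by these compounds alone, putting ((oxolan-3-yl)methyl)amino in place of ((oxan-4-yl)methyl)sulfanyl on this aromatic carbon of the five-membered ring gives a 1.5-fold higher number from compound 2 to compound 3 (0.16 log units; within the scatter), the first change at this position that can be read in one place. The entering group has a nitrogen link, a five-membered non-aromatic ring and 1 hydrogen-bond donor, whereas the leaving group has a sulfur link, a six-membered non-aromatic ring and 0 hydrogen-bond donors, yet these differences taken together leave compound 2 and compound 3 within the scatter of each other. Nothing available offers an explanation for this result.

On these data alone, because the link and the ring changed in a single step, what each contributes on its own remains open, a question that ((oxan-4-yl)methyl)amino or ((oxolan-3-yl)methyl)sulfanyl on the core of compound 2 would address. As far as these compounds go, it is also open whether the same reading would hold for an oxygen link, as in (oxan-4-yl)methoxy, or for a longer chain between the link and the ring.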